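A few compounds are considered here, and "the series" means these few. Any claim that something is new, unique, unknown or untested is made for them only; others in the source may bear on it.

Compound 1 `O=C(CSc1nc(Nc2ccccc2)c2ccccc2n1)Nc1ccc(Cl)cc1` and compound 2 `O=C(CSc1nc(Nc2ccccc2)c2ccccc2n1)Nc1ccc(Br)cc1` share one core, and compound 3 `C=CC(=O)Nc1cccc(NC(=O)CSc2nc(Nc3ccccc3Cl)c3ccccc3n2)c1` carries a different core; the difference between the two cores is not broken down here. In a functional assay on PC-3 cells (Homo sapiens) for inhibition, read by MTT assay, with a stated time of 72 h (a lower number here means a stronger inhibitor, a higher number a weaker inhibitor), compound 1 gives 12900 nM, compound 2 gives 8450 nM, and compound 3 gives 14400 nM. The change bromo in place of chloro on an aromatic carbon made a step of a 1.5-fold lower number from compound 1 to compound 2 (0.18 log units; within the scatter). Compound 4 `C=CC(=O)Nc1cccc(NC(=O)CSc2nc(Nc3ccccc3Br)c3ccccc3n2)c1` is not yet measured; it differs from compound 3 by bromo in place of chloro on an aromatic carbon, the same kind of change, though here the place is ortho to a large group rather than para to a large group. Because the earlier step of a 1.5-fold lower number from compound 1 to compound 2 (0.18 log units; within the scatter) stayed within the scatter, the step from compound 3 to compound 4 is expected to be similar, about a 1.3-fold lower number from compound 3 to compound 4 (0.12 log units; within the scatter). Compound 4 is therefore estimated at 11000 nM in this assay, within 5000 nM to 25000 nM.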

Compound 4, half-maximal inhibitory concentration: 17100 nM
Compound 4: the middle estimate sits 1.6-fold (0.19 log units) below what was measured; low and high end bracket the measured number.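

In this assay, bromo in place of chloro made a step of a 1.2-fold higher number from compound 3 to compound 4 (0.07 log units; within the scatter). Set beside the same change on the other core, the two steps cannot be told apart: the same change on two cores in this assay, a 1.5-fold lower number (0.18 log units; within the scatter) from compound 1 to compound 2 and a 1.2-fold higher number (0.07 log units; within the scatter) from compound 3 to compound 4, 1.8-fold (0.26 log units) apart, within the scatter of two such steps. So on these two cores the swap carried over as a step too small to read, but this does not show that the cores respond alike to changes in general, since neither step rises above the scatter and the halogen sits at a different place on each core.

The compounds shown compare only chloro and bromo. Going by these compounds, whether a fluoro, a methoxy or an amine at the same place would move the number beyond the scatter remains open.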